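The source may report more compounds than this note shows. Statements on the series, on what has been measured and on what is new or still open speak of the compounds shown alone.

Measured in an ADME assay on cells (Erythrocyte, Homo sapiens), read by spectrophotometry and hemolysis, with a stated time of 24 h; on this read-out higher numbers stand for weaker inhibition and lower numbers for stronger inhibition:
Compound 1 `CC(=O)c1ccccc1OCc1ccc2no[n+]([O-])c2c1`: > 200 uM
Compound 2 `CC1(C)[N+]([O-])=c2ccc(COc3cccc(C=O)c3)cc2=[N+]1[O-]`: < 50 uM
Compound 3 `[O-][n+]1onc2ccc(COc3ccc(/C=N/NC(=S)Nc4ccccc4)cc3)cc21`: "nd(insoluble)" (no result reported)

Compound 1 has no exact number, only a limit: > 200 uM. This entry is the limit of > 200 uM in this assay, at which 1 of the 3 values shown sits. Compound 2 is also known only as a limit: < 50 uM. Compound 3 gives no number: "nd(insoluble)" (no result reported). Within the data shown here, the three measured compounds therefore offer no exact value to anchor the series, and no pair among them differs in one place only.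

The next compound is compound 4 `NC(=O)N/N=C\c1ccccc1OCc1ccc2no[n+]([O-])c2c1`. It keeps the core of compound 1, but the acetyl on an aromatic carbon of a six-membered aromatic ring of carbon only, ortho to a large group, is replaced by a group of 6 heavy atoms (2 carbon, 3 nitrogen, 1 oxygen; no ring): a group of 6 heavy atoms (2 carbon, 3 nitrogen, 1 oxygen; no ring) in place of a group of 3 heavy atoms (2 carbon, 1 oxygen; no ring), on an aromatic carbon.

Among the measured compounds shown here, with no measured step to scale this change, no step beyond the usual scatter is expected in this assay. Any movement is expected to be toward stronger inhibition, as compound 1 starts from > 200 uM. The estimated change is an at least 1.1-fold lower number from compound 1 to compound 4 (0.04 log units; that floor lies within the scatter). For compound 4 the expected value is 180 uM, with an estimated range of 70 uM to 400 uM.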

Compound 4, concentration for 50% inhibition: > 100 uM
Compound 4: only a limit was reported (the forecaster's own chance of this, stated with the estimate: 55%); the middle value is on the limit's open side.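

In this assay compound 1 and compound 4 are both known only as limits, and the step between them cannot be read. The compounds shown leave open whether putting the group of 6 heavy atoms in place of the acetyl, on an aromatic carbon, changes the read-out at all, and in which direction.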